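The compounds below may be only part of what the source reports. "The series", "measured", "known", "first", "only" and "open" are said of these compounds alone.

Measured so far in a functional assay on HeLa cells (Homo sapiens) for cytotoxicity, read by MTT assay, with a stated time of 24 h; on this read-out higher numbers stand for weaker inhibition and lower numbers for stronger inhibition:
compound 1 `CCCCCCCC/C=C\CCCCCCCC(=O)Nc1nnc(S[C@@H]2O[C@H](COC(C)=O)[C@H](OC(C)=O)[C@H](OC(C)=O)[C@H]2OC(C)=O)s1` gives 54400 nM
compound 2 `CCCCCCCCCCCC(=O)Nc1nnc(S[C@@H]2O[C@H](CO)[C@H](O)[C@H](O)[C@H]2O)s1` gives 8700 nM
compound 3 `CCCCCCCCCCCCCCCC(=O)Nc1nnc(S[C@@H]2O[C@H](CO)[C@H](O)[C@H](O)[C@H]2O)s1` gives 14200 nM

Compound 1 has the highest number of the three in this assay; its gap to compound 3 and its gap to compound 2 both lie beyond the scatter, so compound 1 is the weakest inhibitor of the measured set. Compound 2 and compound 3 differ only in the chain, and that step a 1.6-fold higher number from compound 2 to compound 3 (0.21 log units; within the scatter) is within the scatter. Among the measured compounds shown here, compound 1 also carries four acetyl groups on the sugar where compound 2 and compound 3 carry free hydroxyls; no step isolates that change, and only the values themselves speak for it.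

Compound 4 `C=CCCCCCCCCC(=O)Nc1nnc(S[C@@H]2O[C@H](COC(C)=O)[C@H](OC(C)=O)[C@H](OC(C)=O)[C@H]2OC(C)=O)s1` arises from compound 1 by allyl in place of dec-1-en-1-yl on a saturated chain carbon, seven bonds along the chain from a carbonyl carbon. For the measured compounds named here, the only measured step that bears on it is the chain change between compound 2 and compound 3, which was within the scatter. The step from compound 1 to compound 4 is therefore expected to be small, with a slight lean toward a lower number, expected as a 1.2-fold lower number from compound 1 to compound 4 (0.08 log units; within the scatter). Compound 4 is estimated at 45000 nM, with a range from 15000 nM to 130000 nM.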

Compound 4, half-maximal inhibitory concentration: 77700 nM
Compound 4: middle estimate off by 1.7-fold (0.24 log units), on the low side; measured number inside the range.
By their numbers in this assay, from the lowest: compounds 2 and 3 (each within the scatter of the next); then compounds 1 and 4 (each within the scatter of the next).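

In this assay, replacing dec-1-en-1-yl with allyl on a saturated chain carbon, seven bonds along the chain from a carbonyl carbon, gives a 1.4-fold higher number from compound 1 to compound 4 (0.15 log units; within the scatter) and so removes seven carbon atoms without a step beyond the scatter. The earlier step, a 1.6-fold higher number from compound 2 to compound 3 (0.21 log units; within the scatter), covered only butyl in place of hydrogen on compounds with free sugar hydroxyls; the chain now also shows no step beyond the scatter on compounds with four acetyl groups on the sugar, and no listed step goes against this. No supporting data bear on this result.

Among the compounds shown here, no pair differs only in the acetyl groups, so their separate contribution remains open. Also open, on these data alone, is how an amine or a carboxylic acid in place of allyl at this position would read in this assay on this series.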